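Adding a methoxy to the phenoxy group of compound 3

The compounds below may be only part of what the source reports. "The series", "measured", "known", "first", "only" and "open" are said of these compounds alone.

Of the compounds shown here, three share one core and have been measured in a physicochemical assay for acid dissociation. Compound 1 `COc1ccc(F)cc1CNCCCNc1ccnc2cc(-c3ccc(F)cc3)ccc12` gives 9.47, compound 2 `COc1ccc(F)cc1CNCCCNc1ccnc2cc(Cc3ccccc3)ccc12` gives 9.47, and compound 3 `COc1ccc(F)cc1CNCCCNc1ccnc2cc(Oc3ccccc3)ccc12` gives 9.28. Compound 3 stands apart from the other two only by a number 0.19 log units lower from compound 1 to compound 3 (within the scatter) and a number 0.19 log units lower from compound 2 to compound 3 (within the scatter), so all three numbers sit together within the usual scatter; swapping the group on that aromatic carbon has left the read-out essentially untouched so far, as no change at the digits printed from compound 1 to compound 2 (within the scatter) also shows.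

Compound 4 `COc1ccc(F)cc1CNCCCNc1ccnc2cc(Oc3ccccc3OC)ccc12` differs from compound 3 by methoxy in place of hydrogen on an aromatic carbon. For the measured compounds named here, no measured step places a methoxy on this ring, so the nearest guidance comes from the three steps above, each of which changed the group at that position without moving the number beyond the scatter. The expectation is therefore a step of a number 0.02 log units higher from compound 3 to compound 4 (within the scatter) in this assay, that is, no change beyond the scatter. Compound 4 is estimated at 9.3, within a range from 9 to 9.6.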

Compound 4, acid dissociation constant: 9.28
The estimate for compound 4 lay 0.02 log units above the measured number, within the range that was stated.
By their numbers in this assay, from the lowest: compounds 3, 4, 1 and 2 (each within the scatter of the next).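

In this assay, for the compounds shown here, the earlier steps only swapped one group for another at this aromatic carbon, whereas this step adds a methoxy to the phenoxy group, ortho to a large group, and no change at the digits printed from compound 3 to compound 4 (within the scatter) is the outcome, so adding to the group leaves the read-out as unmoved as exchanging it did. Measured against the other two groups, 2-methoxyphenoxy gives a number 0.19 log units lower from compound 2 to compound 4 (within the scatter) and a number 0.19 log units lower from compound 1 to compound 4 (within the scatter) as well, so all four numbers sit together. Nothing available here offers an explanation for this flat result.

From the compounds shown here alone, whether an amine or a carboxylic acid in place of the methoxy would carry the number beyond the scatter remains open. So does the question of whether a longer chain on the same ring would do so.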